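This account rests on a few compounds, and the source may have more. Where it says the series, first, only, none or still open, it means among the compounds named here.

Among the measured compounds shown here, in an ADME assay on microsomes from liver (Rattus norvegicus) for metabolic stability (a higher number here means that the compound lasts longer, a lower number that the compound disappears faster), compound 2 (`CC#C[C@@H](Cc1nnn[nH]1)c1ccc(OCc2ccc3sc(C)c(-c4ccc(OCCOC)cc4C)c3c2)cc1`) gives 0.117 h, the lowest of the two numbers so far. Compound 1 (`CC#C[C@@H](Cc1nnn[nH]1)c1ccc(OCc2ccc3scc(-c4cc(OCCOC)ccc4C)c3c2)cc1`) gives 0.367 h and so lasts longer, a gap beyond the usual scatter. Compound 3 (`CC#C[C@@H](Cc1nnn[nH]1)c1ccc(OCc2ccc3scc(-c4ccc(OCCOC)cc4C)c3c2)cc1`) is compound 2 with one change (hydrogen in place of methyl on an aromatic carbon): hydrogen in place of methyl on an aromatic carbon, next to the ring sulfur. For the measured compounds named here, no measured pair shows this change alone. Hydrogen also sits on that carbon in compound 1 at 0.367 h, but other parts of that structure differ, so it is only a loose guide. A modest rise in this assay is expected, with an estimated 2.0-fold higher number from compound 2 to compound 3 (0.29 log units; within the scatter) near the edge of the scatter. For compound 3 the expected half-life is 0.23 h (estimated range 0.11 h to 0.48 h).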

Compound 3, half-life: 0.217 h
Compound 3: middle estimate off by 1.1-fold (0.03 log units), on the high side, and the stated range covers the measured number.
By their numbers in this assay, from the lowest: compounds 2, 3 and 1 (each within the scatter of the next, the first and the last beyond it).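

In this assay, the first direct test of hydrogen in place of methyl on this aromatic carbon, next to the ring sulfur, gives a 1.9-fold higher number from compound 2 to compound 3 (0.27 log units; within the scatter), so on this evidence the methyl can go without a shift clear of the scatter. Having 4-(2-methoxyethoxy)-2-methylphenyl in place of 5-(2-methoxyethoxy)-2-methylphenyl gives a 1.7-fold lower number from compound 1 to compound 3 (0.23 log units; within the scatter), so this single change also stays within the scatter. Nothing measured here explains either step.

Going by these compounds, only hydrogen and methyl appear on this carbon, so the effect of a chlorine, a methoxy group or an amine there remains open. On these data alone, it is also open whether hydrogen in place of methyl gives a similar step alongside the 5-(2-methoxyethoxy)-2-methylphenyl group of compound 1.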